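This account rests on a few compounds, and the source may have more. Where it says the series, first, only, none or still open, it means among the compounds named here.

Of the compounds shown here, three have so far been measured in a functional assay for inhibition, with Homo sapiens as the target; a lower number here means a stronger inhibitor, a higher number a weaker inhibitor. Compound 1 `CN(C)c1ccccc1Nc1nccc(-c2ccncc2)n1` gives 36200 nM. Compound 2 `c1ccc(Nc2nccc(-c3ccncc3)n2)cc1` gives 900 nM, and compound 3 `CC(=O)N(C)c1ccc(Nc2nccc(-c3ccncc3)n2)cc1` gives 500 nM. Among these three numbers compound 2 stands second highest; its nearest neighbour is compound 3, with a 1.8-fold lower number from compound 2 to compound 3 (0.26 log units; within the scatter), and its furthest is compound 1, with a 40-fold lower number from compound 1 to compound 2 (1.60 log units; beyond the scatter).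

Compound 4 `Cc1ccccc1Nc1nccc(-c2ccncc2)n1` has not yet been measured. It differs from compound 2 in one place: methyl in place of hydrogen on an aromatic carbon. The entering group sits ortho to a large group, on a six-membered aromatic ring of carbon only. Among the compounds with values here, the only measured step that bears on this change is a 40-fold lower number from compound 1 to compound 2 (1.60 log units; beyond the scatter), in which a dimethylamino left that same place. A group entering there is therefore expected to raise the number again, though methyl is a different group, so the rise is expected to be smaller than that step. Compound 4 is expected to give 3000 nM, within a range from 900 nM to 12000 nM. This amounts to an expected step of a 3.3-fold higher number from compound 2 to compound 4 (0.52 log units; beyond the scatter).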

Compound 4, half-maximal inhibitory concentration: 3900 nM
For compound 4 the middle estimate is 1.3-fold (0.11 log units) below the measured one; the measured number falls inside the stated range.
By their numbers in this assay, from the lowest: compounds 3 and 2 (each within the scatter of the next); then compound 4; then compound 1.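

In this assay, even a single methyl on this aromatic carbon, ortho to a large group, weakens inhibition, with a 4.3-fold higher number from compound 2 to compound 4 (0.64 log units; beyond the scatter). The higher number seen with dimethylamino at this place is therefore not unique to that group. Methyl is still clearly better tolerated than dimethylamino, with a 9.3-fold lower number from compound 1 to compound 4 (0.97 log units; beyond the scatter), so the identity of the entering group matters here as well as its presence, though nothing measured here explains either step.

The compounds shown leave open how an ethyl, a methoxy, a chlorine or a primary amine at this same place would compare with methyl and dimethylamino. Going by these compounds, it also remains open whether methyl brings a similar step when the acetyl(methyl)amino group of compound 3 is present.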